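The compounds below may be only part of what the source reports. "The series", "measured", "known", "first", "only" and "open" are said of these compounds alone.

Compound 1 `O=S(=O)(c1cc(F)cc(F)c1)c1cnc2cc(F)ccc2c1-c1ccc(Cl)cc1` gives 0.03 mL/min in an ADME assay on microsomes from liver (Homo sapiens) for metabolic stability, tested at 2.5 uM; a higher number here means faster removal of the compound, a lower number slower removal.
Compound 2 `O=S(=O)(c1cc(F)cc(F)c1)c1cnc2cc(F)ccc2c1-c1cccc(Cl)c1` gives 0.22 mL/min in this assay.

Going by the values given here, of the two numbers measured so far, compound 2 holds the higher one. Among the compounds with values here, the only step between measured compounds, a 7.3-fold higher number from compound 1 to compound 2 (0.87 log units; beyond the scatter), concerns 3-chlorophenyl in place of 4-chlorophenyl on an aromatic carbon and is judged modest. Compound 3 `Cc1ccc(S(=O)(=O)c2cnc3cc(F)ccc3c2-c2cccc(Cl)c2)cc1C` differs from compound 2 at another place: 3,4-dimethylphenyl in place of 3,5-difluorophenyl on a sulfonyl sulfur. That change sits on the sulfonyl sulfur rather than on the aromatic carbon varied between compound 1 and compound 2. Within the data shown here, the one measured step does not bear on it, and the data give no measured pair from which a direction in this assay could be read. Starting from the number of compound 2, the step is therefore expected to be a 1.4-fold higher number from compound 2 to compound 3 (0.13 log units; within the scatter), of uncertain direction and possibly within the scatter. For compound 3 the estimate is 0.3 mL/min, with a range from 0.08 mL/min to 1 mL/min.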

Compound 3, intrinsic clearance in a liver preparation (reported as CLH), per the amount of preparation that the assay uses: 4.01 mL/min
Beside the measured number, compound 3's estimate is 13-fold (1.13 log units) below it; measured number above the stated range.
By their numbers in this assay, from the lowest: compound 1; then compound 2; then compound 3.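

The group on the sulfonyl sulfur turns out to matter in this assay: 3,4-dimethylphenyl in place of 3,5-difluorophenyl gives an 18-fold higher number from compound 2 to compound 3 (1.26 log units; beyond the scatter). This step is judged large, whereas the only earlier step, on the aromatic carbon, a 7.3-fold higher number from compound 1 to compound 2 (0.87 log units; beyond the scatter), is judged modest, so among these three compounds the sulfonyl sulfur position produces the greater change. Nothing measured here explains the size of this step.

The compounds shown leave open whether the two methyl groups or the loss of the two fluorines drives this step, and whether it would appear equally with the 4-chlorophenyl of compound 1. From the compounds shown here alone, how this assay would respond to an amine or a carboxylic acid on the phenyl ring at the sulfonyl sulfur also remains open.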